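Cytotoxicity notes on a nucleoside series

The compounds below may be only part of what the source reports. "The series", "measured", "known", "first", "only" and "open" are said of these compounds alone.

Measured compounds:
compound 1, `CS[C@H]1O[C@@H](n2cnc3c(N)nc(F)nc32)[C@H](O)[C@@H]1O`: 580 nM
compound 2, `CS[C@H]1O[C@@H](n2cnc3c(N)nc(C#N)nc32)[C@H](O)[C@@H]1O`: 153000 nM
compound 3, `CNc1nc(C#N)nc2c1ncn2[C@@H]1O[C@H](C)[C@@H](O)[C@H]1O`: 85000 nM

All three values come from an ADME assay on L6 cells (Rattus norvegicus) for cytotoxicity; on this read-out higher numbers stand for weaker inhibition and lower numbers for stronger inhibition. Compound 2 and compound 3 differ in more than one place, and the difference between their two cores is not broken down here; in this assay compound 2 gives 153000 nM and compound 3 gives 85000 nM, which lie within the scatter of each other.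

One change is seen once and now recurs. From compound 2 to compound 1 the change is fluoro in place of cyano on an aromatic carbon, and it gives a 260-fold lower number from compound 2 to compound 1 (2.42 log units; beyond the scatter). Compound 4, `CNc1nc(F)nc2c1ncn2[C@@H]1O[C@H](C)[C@@H](O)[C@H]1O`, not yet measured in this assay, arises from compound 3 by fluoro in place of cyano on an aromatic carbon. The two place lines agree except that the substituted carbon is meta to an amino group in the first case and meta to a methylamino group in the second, so this is the same kind of change rather than the same one.

On that basis compound 4 is expected to move by about a 170-fold lower number from compound 3 to compound 4 (2.23 log units; beyond the scatter), the expectation resting on the step of a 260-fold lower number from compound 2 to compound 1 (2.42 log units; beyond the scatter), with compound 3 at 85000 nM as its start. Compound 4 is estimated at 500 nM, expected between 120 nM and 3000 nM.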

Compound 4, half-maximal inhibitory concentration: 236000 nM
For compound 4 the middle estimate is 470-fold (2.67 log units) below the measured one; the measured number lies above the stated range.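

In this assay, fluoro in place of cyano on an aromatic carbon gives a 2.8-fold higher number from compound 3 to compound 4 (0.44 log units; beyond the scatter), so the large fall in the number seen on the core of compound 1 does not carry over to the core of compound 4. Among these compounds, the result shows that a step measured for this change on one core cannot be transferred to the other, but it does not show which difference between the cores is responsible, as compound 2 and compound 3 differ in more than one place and each core supplies only one pair. The two steps differ in direction and in size, and the gap lies beyond the scatter: the same change on two cores in this assay, a 260-fold lower number (2.42 log units; beyond the scatter) from compound 2 to compound 1 and a 2.8-fold higher number (0.44 log units; beyond the scatter) from compound 3 to compound 4, 730-fold (2.86 log units) apart, beyond the scatter of two such steps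

Still open, as far as these compounds go, is whether the methylamino group in place of the amino group, or the other difference between the cores, decides the outcome. Also open, from the compounds shown here alone, is how a chloro group or a carboxamide on the same aromatic carbon would read on either core.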